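Shortening an acid chain on the shared core

A few compounds are considered here, and "the series" means these few. Any claim that something is new, unique, unknown or untested is made for them only; others in the source may bear on it.

Compound 1: `Cc1c(Cl)cccc1CCCCOc1ccc(C#Cc2cccc3c(CCCC(=O)O)c(C)n(CCC(=O)O)c23)cc1` gives 22 nM in a functional assay on HEK293 cells for antagonist activity at cysteinyl leukotriene receptor 2 (Homo sapiens), read by fluorescence and calcium flux, with stated times of 30 min and 1 h; a higher number here means a weaker inhibitor, a lower number a stronger inhibitor.
Compound 2: `Cc1c(Cl)cccc1CCCCOc1ccc(C#Cc2cccc3c(CCCC(=O)O)c(C)n(CCCCC(=O)O)c23)cc1` gives 30 nM in this assay.

Among the two compounds measured so far, compound 2 has the higher number, but the difference a 1.4-fold higher number from compound 1 to compound 2 (0.13 log units; within the scatter) is within the scatter, so the two cannot be ordered. Compound 3 is `Cc1c(Cl)cccc1CCCCOc1ccc(C#Cc2cccc3c(CC(=O)O)c(C)n(CCCCC(=O)O)c23)cc1` and has not yet been measured. It differs from compound 2 in one place: carboxy in place of 2-carboxyethyl on a saturated chain carbon bound to an aromatic carbon. In words, the chain bearing the acid on the carbon side of the core is cut short, while everything else, including the chain on the aromatic nitrogen, stays as in compound 2.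

Among the measured compounds shown here, the only measured step, from compound 1 to compound 2, changed the acid chain on the nitrogen, not the one changed here, and it stayed within the scatter. It shows that one acid chain on this core tolerates a change in length, but says nothing directly about the chain on the carbon side. For the measured compounds named here, with no closer precedent, the expectation is a modest weakening at most, a 1.5-fold higher number from compound 2 to compound 3 (0.18 log units; within the scatter), with wide uncertainty. Compound 3 is therefore estimated at 45 nM, within a range from 15 nM to 150 nM.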

Compound 3, half-maximal inhibitory concentration: 248 nM
For compound 3 the middle estimate is 5.5-fold (0.74 log units) below the measured one; the measured number lies above the stated range.
By their numbers in this assay, from the lowest: compounds 1 and 2 (each within the scatter of the next); then compound 3.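

Cutting 3-carboxypropyl back to carboxymethyl, on a saturated chain carbon bound to an aromatic carbon, gives an 8.3-fold higher number from compound 2 to compound 3 (0.92 log units; beyond the scatter) in this assay. Among the compounds shown here, this is the first step that lies beyond the scatter, and it shows that the length of this acid chain matters on the shared core, at least with the rest of compound 2 held fixed. The two acid chains therefore do not behave alike in these compounds, since the change to the chain on the aromatic nitrogen gave only a 1.4-fold higher number from compound 1 to compound 2 (0.13 log units; within the scatter), whereas the one on the carbon side cannot be cut this far without a clear rise in the number; nothing available here accounts for that difference.

As far as these compounds go, it remains open whether a 2-carboxyethyl chain at this place would keep the number of compound 2 or share the loss seen with compound 3, and whether a longer chain ending in a carboxylic acid would do any better. From the compounds shown here alone, it is also open whether carboxymethyl would give a similar step when paired with the shorter acid chain on the nitrogen found in compound 1.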